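This account rests on a few compounds, and the source may have more. Where it says the series, first, only, none or still open, it means among the compounds named here.

Measured so far:
compound 1, `O=C(O)[C@H]1NC[C@H](O)[C@H](O)[C@@H]1O`, 4.5%
compound 2, `O=C(O)[C@@H]1NC[C@H](O)[C@@H](O)[C@H]1O`, 4%

Both numbers come from an assay for inhibition of alpha-N-acetylgalactosaminidase (Gallus gallus), tested at 1000 uM; on this read-out higher numbers stand for more inhibition at the one concentration tested (going by the name of the read-out) and lower numbers for less inhibition. Compound 2 stands alongside compound 1 rather than apart from it: the step of a number 0.5 percentage points lower from compound 1 to compound 2 (within the scatter) lies within the scatter, so the two cannot be told apart on these data.

The next compound, compound 3 `O=C(O)[C@@H]1NC[C@@H](O)[C@H](O)[C@@H]1O`, is reached from compound 2 by a change of configuration alone: the two compounds have the same atoms and bonds and differ only in configuration as drawn: 3 of 4 stereo elements differ; a stereocentre at a saturated ring carbon is drawn S in compound 2 and R in compound 3; a stereocentre at a saturated ring carbon is drawn R in compound 2 and S in compound 3; a stereocentre at a saturated ring carbon is drawn S in compound 2 and R in compound 3.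

Within the data shown here, only one measured step speaks to such a change. The step of a number 0.5 percentage points lower from compound 1 to compound 2 (within the scatter) was itself a pure rearrangement of stereocentres, (the fact that compounds 1 and 2 differ only in the configuration as drawn), and it produced nothing beyond the scatter. On that single precedent the expected step of no change at the digits printed from compound 2 to compound 3 (within the scatter) in this assay is none beyond the scatter, in no particular direction. Compound 3 is therefore estimated at 4%, with a range from -4% to 13%.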

Compound 3, a percentage reported as inhibition, at one concentration (the size of the read-out at that concentration, not a potency): 10%
Compound 3: middle estimate off by 6 percentage points, on the low side; low and high end bracket the measured number.
By their numbers in this assay, from the lowest: compounds 2, 1 and 3 (each within the scatter of the next).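

With compound 3, the set in this assay gains two further steps of pure configuration, a number 6 percentage points higher from compound 2 to compound 3 (within the scatter) and a number 5.5 percentage points higher from compound 1 to compound 3 (within the scatter), and neither goes beyond the scatter. The earlier compounds had shown this for only one rearrangement, whereas the data now cover a change at three of the four stereo elements and another at two of them, with the atoms and bonds unchanged in both: the fact that compounds 2 and 3 differ only in the configuration as drawn The second of these new comparisons rests on the same kind of structural relation: the fact that compounds 1 and 3 differ only in the configuration as drawn

Which single stereocentre, if any, matters on its own stays open, as no pair shown differs at only one. Also open, on these data alone, is whether replacing the carboxylic acid with a hydroxymethyl group, or adding a longer chain on the nitrogen, would move the number beyond the scatter.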